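Pyrrolidinyl in place of dimethylamino: expected effect

A few compounds are considered here, and "the series" means these few. Any claim that something is new, unique, unknown or untested is made for them only; others in the source may bear on it.

Among the measured compounds shown here, compound 2 `Cc1nnc(CN(C)C)n1-c1ccc(Cl)cc1C(=O)c1ccccc1` gives 0.5 mg/kg in a functional assay on the whole organism (strain CF-1) for inhibition, with Mus musculus as the target (on this read-out higher numbers stand for an effect only at larger amounts of compound and lower numbers for an effect already at smaller amounts), the lowest of the two numbers so far. For the measured compounds named here, compound 1 `Cc1nnc(CN2CCCC2)n1-c1ccc(Cl)cc1Cc1ccccc1` gives 36 mg/kg in this assay, but it differs from compound 2 in more than one place, so no single step is read from that pair. Compound 3 `Cc1nnc(CN2CCCC2)n1-c1ccc(Cl)cc1C(=O)c1ccccc1` differs from compound 2 by pyrrolidin-1-yl in place of dimethylamino on a saturated chain carbon bound to an aromatic carbon. Going by the values given here, no measured pair isolates this change; the step is expected to be small, likely within the scatter, leaning toward a higher number. For compound 3 the estimate in this assay is 1 mg/kg, between 0.3 mg/kg and 4 mg/kg. This corresponds to an expected step of a 2.0-fold higher number from compound 2 to compound 3 (0.30 log units; within the scatter).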

Compound 3, dose for half-maximal effect: 0.4 mg/kg
Beside the measured number, compound 3's estimate is 2.5-fold (0.40 log units) above it; the measured number falls inside the stated range.
By their numbers in this assay, from the lowest: compounds 3 and 2 (each within the scatter of the next); then compound 1.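

In this assay the step of a 1.3-fold lower number from compound 2 to compound 3 (0.10 log units; within the scatter) shows that pyrrolidin-1-yl in place of dimethylamino on a saturated chain carbon bound to an aromatic carbon stays within the scatter, so a five-membered ring is accepted at this position. Benzoyl in place of benzyl on an aromatic carbon, now readable as a single change, gives a 90-fold lower number from compound 1 to compound 3 (1.95 log units; beyond the scatter) in this assay and is the large step of the series so far. No measurement shown gives a reason for either step.

Larger amine rings on the same chain carbon, such as piperidin-1-yl or morpholin-4-yl, remain open. So does whether benzyl in place of benzoyl produces a step of similar size with dimethylamino on the chain.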